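Working notes: from compound 3 to compound 4

The source may hold more compounds than are shown below. What is called first, only, known or untested is meant among the compounds shown, and "the series" means these compounds.

Measured so far in an ADME assay on Raji cells (Homo sapiens) for cytotoxicity, with a stated time of 72 h; on this read-out higher numbers stand for an effect only at larger amounts of compound and lower numbers for an effect already at smaller amounts:
- compound 1 `Cc1ccc(NC(=O)Nc2cc(C)nc3ccccc23)cc1` reads > 25000 nM as a limit
- compound 2 `Cc1cc(NC(=O)Nc2ccc(F)cc2)c2ccccc2n1` reads > 25000 nM as a limit
- compound 3 `Cc1cc(NC(=O)Nc2cccnc2)c2ccccc2n1` reads > 25000 nM as a limit

Compound 3 stands at > 25000 nM in this assay and that is a limit, not a number. The set as a whole shows the limit of > 25000 nM in this assay, at which 3 of the 3 values shown sit, and so gives no ranking.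

Compound 4 `Cc1cc(NC(=O)Nc2ccccc2F)c2ccccc2n1` follows with the change 2-fluorophenyl in place of pyridin-3-yl on an amide-type nitrogen in which 2-fluorophenyl takes the place of pyridin-3-yl on an amide-type nitrogen.

The closest measured change is a step that the two limits leave unreadable from compound 2 to compound 3 on an amide-type nitrogen, and a step that the two limits leave unreadable from compound 1 to compound 3 is of the same kind. The remaining one, a step that the two limits leave unreadable from compound 1 to compound 2 on an aromatic carbon, bears on it less directly. None of these has a readable size, so no size or direction carries over. In this assay nothing beyond the scatter is expected, and another limit is the likeliest reading. The expected change is a step that the limit leaves unreadable from compound 3 to compound 4 with no direction favoured. For compound 4 the estimate is 30000 nM with an expected range from 12000 nM to 60000 nM as the working figure.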

Compound 4, half-maximal effective concentration: > 25000 nM
Compound 4 ended at the assay's limit (the forecaster's own chance of this, stated with the estimate: 85%); the middle value lies beyond the limit too.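

No new step between compound 4 and compound 1, compound 2 or compound 3 can be read in this assay: the limit of > 25000 nM in this assay, at which 4 of the 4 values shown sit.

The compounds shown leave open any ranking among compound 1, compound 2, compound 3 and compound 4, and whether the group on the amide-type nitrogen alters this read-out at all.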